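Saturated versus alkyne ether chains on the aminoquinoline core

A few compounds are considered here, and "the series" means these few. Any claim that something is new, unique, unknown or untested is made for them only; others in the source may bear on it.

Measured compounds in an assay on cells with melanin-concentrating hormone receptor 1 (Homo sapiens) as the target, read by radioligand binding; on this read-out lower numbers stand for stronger inhibition and higher numbers for weaker inhibition:
compound 1, `CCCCOc1cccc2ccc(N)nc12`, 789 nM
compound 2, `CCCOc1cccc2ccc(N)nc12`, 1100 nM
compound 3, `CCC#CCOc1cccc2ccc(N)nc12`, a limit only

Compound 3 sits at the limit of this assay, > 2000 nM, which is a limit and not a number (the limit of > 2000 nM in this assay, at which 1 of the 3 values shown sits). Compound 4, `CCCC(C)Oc1cccc2ccc(N)nc12`, differs from it by 1-methylbutyl in place of pent-2-yn-1-yl on an oxygen on an aromatic ring. For the measured compounds named here, the steps that bear on this are an at least 2.5-fold higher number from compound 1 to compound 3 (0.40 log units; beyond the scatter) and an at least 1.8-fold higher number from compound 2 to compound 3 (0.25 log units; that floor lies within the scatter), both going towards weaker inhibition when a chain carrying a triple bond replaces a saturated one. Returning to a saturated chain is therefore expected to give a step towards lower numbers in this assay, estimated as an at least 2.2-fold lower number from compound 3 to compound 4 (0.34 log units; beyond the scatter). Compound 4 is estimated at 900 nM, with a range from 400 nM to 2000 nM.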

Compound 4, half-maximal inhibitory concentration: 105 nM
Estimate against measurement, compound 4: 8.6-fold (0.93 log units) above, and the stated range ends above it.
By their numbers in this assay, from the lowest: compound 4; then compounds 1 and 2 (each within the scatter of the next). At a limit, above all of these: compound 3.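

Among the saturated chains, shortening alone moved little, whereas methyl in place of hydrogen on the saturated chain carbon bound to the oxygen matters in this assay (a 7.5-fold lower number from compound 1 to compound 4 (0.88 log units; beyond the scatter)), and 1-methylbutyl in place of propyl does too (a 10-fold lower number from compound 2 to compound 4 (1.02 log units; beyond the scatter)). Against pent-2-yn-1-yl, the step is larger still on its printed floor (an at least 19-fold lower number from compound 3 to compound 4 (1.27 log units; beyond the scatter)). Compound 3 stands at a limit and not a number, so that step is only a floor: the limit of > 2000 nM in this assay, at which 1 of the 4 values shown sits.

As far as these compounds go, compound 4 is the only branched chain here, so whether the gain holds for a shorter 1-methylpropyl or a longer 1-methylpentyl stays open. Also open, from the compounds shown here alone, is whether a chain ending in an amine or a carboxylic acid keeps it.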